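The source may report more compounds than this note shows. Statements on the series, on what has been measured and on what is new or still open speak of the compounds shown alone.

Three analogues sharing one core have been tested in a toxicity assay on THP-1 cells (Homo sapiens) for inhibition; on this read-out higher numbers stand for lower toxicity in this test and lower numbers for higher toxicity in this test. Compound 1 `COc1ccc(-c2cnc(NC(=O)c3ccc(F)cc3)n2C)cc1` sits at a limit, giving >= 50000 nM in this assay. Compound 2 `COc1ccc(-c2cnc(NC(=O)c3cnc[nH]3)n2C)cc1` likewise sits at a limit, with > 100000 nM in this assay. Compound 3 `CCC(=O)Nc1ncc(-c2ccc(OC)cc2)n1C` also returns only a limit in this assay, namely > 100000 nM. Compound 3 thus rests at the limit of > 100000 nM in this assay, at which 2 of the 3 values shown sit, and compound 1 at the limit of >= 50000 nM in this assay, at which 1 of the 3 values shown sits. For the measured compounds named here, none of the measured steps can be sized: a step that the two limits leave unreadable from compound 1 to compound 2, a step that the two limits leave unreadable from compound 1 to compound 3 and a step that the two limits leave unreadable from compound 2 to compound 3 are all hidden by the two limits. Compound 4 `COc1ccc(-c2cnc(NC(=O)C3CCNCC3)n2C)cc1` carries the change (piperidin-4-yl in place of ethyl on a carbonyl carbon). The measured steps offer no size to carry over, and no step beyond the scatter is expected, the estimated step being a number no higher from compound 3 to compound 4 (the limit leaves the size open). Compound 4 is therefore expected to give about 100000 nM in this assay, within 30000 nM to 300000 nM.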

Compound 4, half-maximal cytotoxic concentration: > 100000 nM
Compound 4: only a limit was reported; the forecaster's own chance of this, stated with the estimate: 80%; the middle value sits exactly at the limit.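

Compound 4 also returns only a limit in this assay, > 100000 nM, so its steps from compound 1, compound 2 and compound 3 cannot be read. The compounds shown leave open whether changing the group on the carbonyl carbon alters this read-out at all.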